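Shortening the long chain on an aziridine sugar conjugate

The source may hold more compounds than are shown below. What is called first, only, known or untested is meant among the compounds shown, and "the series" means these compounds.

Measured so far:
Compound 1, `CCCCCCCCCCCCCCC1(CO[C@@H]2O[C@@H]3CO[C@H](c4ccccc4)O[C@@H]3[C@H](OCc3ccccc3)[C@H]2OCc2ccccc2)CN1S(=O)(=O)c1ccc(C)cc1`: 1000000 nM
Compound 2, `Cc1ccc(S(=O)(=O)N2C(C)C2CO[C@@H]2O[C@@H]3CO[C@H](c4ccccc4)O[C@@H]3[C@H](OCc3ccccc3)[C@H]2OCc2ccccc2)cc1`: 804000 nM
Compound 3, `Cc1ccc(S(=O)(=O)N2CC2(C)CO[C@@H]2O[C@@H]3CO[C@H](c4ccccc4)O[C@@H]3[C@H](O)[C@H]2O)cc1`: 154000 nM

These three compounds were tested in a functional assay on A549 cells (Homo sapiens) for cytotoxicity, read by MTT assay, with a stated time of 48 h; on this read-out higher numbers stand for weaker inhibition and lower numbers for stronger inhibition. Compound 1 gives the highest number of the three, meaning the weakest inhibition. Compound 2 sits close by, and the two are within the usual scatter of each other, so no order can be read between them. Compound 3 gives a number well below that of compound 1, a gap beyond the scatter, so compound 3 inhibits more strongly than compound 1.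

The new compound, compound 4, `CCCCCCCCCC1(CO[C@@H]2O[C@@H]3CO[C@H](c4ccccc4)O[C@@H]3[C@H](OCc3ccccc3)[C@H]2OCc2ccccc2)CN1S(=O)(=O)c1ccc(C)cc1`, is compound 1 with one change: hydrogen in place of pentyl on a saturated chain carbon, nine bonds along the chain from a saturated ring carbon. The long chain of compound 1 is thus cut shorter, while the rest of the molecule stays as it is.

For the measured compounds named here, no measured pair shows how a change of this kind acts in this assay. Compounds 2 and 3 differ from compound 1 in several places at once, so they offer no direct guide. The step from compound 1 to compound 4 is therefore expected to be small, most likely none beyond the scatter, and the estimate is a 1.7-fold lower number from compound 1 to compound 4 (0.22 log units; within the scatter). Compound 4 is expected to give about 600000 nM, within a range from 150000 nM to 1500000 nM.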

Compound 4, half-maximal inhibitory concentration: 154000 nM
For compound 4 the middle estimate is 3.9-fold (0.59 log units) above the measured one; the measured number falls inside the stated range.
By their numbers in this assay, from the lowest: compounds 3 and 4 (each within the scatter of the next); then compounds 2 and 1 (each within the scatter of the next).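

In this assay, for the compounds shown here, putting hydrogen in place of pentyl on a saturated chain carbon, nine bonds along the chain from a saturated ring carbon, gives a 6.5-fold lower number from compound 1 to compound 4 (0.81 log units; beyond the scatter), and this is the first single change on this core that can be read directly. The earlier compounds differ from each other in several places at once, whereas here only the chain differs, so this position is shown to matter and the shorter chain goes with stronger inhibition, by a modest step that lies beyond the usual scatter. Nothing available here explains why removing these chain carbons goes with the lower number.

Going by these compounds, two chain lengths give only a direction, so it remains open whether further shortening would continue the trend, or whether a longer chain would push the number back up. Also open, on these data alone, are the effects of a different kind of group in place of pentyl, such as an amine or a carboxylic acid, and whether the same shortening would act alike on a core that carries free hydroxyl groups instead of the benzyl ethers.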